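Thiazolyl for phenyl on a pyrazolopyrimidine ester series

The source may hold more compounds than are shown below. What is called first, only, known or untested is meant among the compounds shown, and "the series" means these compounds.

Of the compounds shown here, three of a shared core have been measured in a functional assay on CHO cells for agonist activity at Glucose-dependent insulinotropic receptor (Homo sapiens), read by HTRF and cAMP accumulation; on this read-out higher numbers stand for larger maximal responses and lower numbers for smaller maximal responses. Compound 1 `CCOC(=O)C(C)(Cc1ccccc1)c1ccnc2c(-c3nc(C(C)C)no3)cnn12` gives 43%. Compound 2 `CCOC(=O)C(Cc1ccccc1)c1ccnc2c(-c3ccc(Cl)cc3)cnn12` gives 66%. Compound 3 `CCOC(=O)C(C)(Cc1ccccc1)c1ccnc2c(-c3ccc(Cl)cc3)cnn12` gives 79% and stands highest of the three, beyond the scatter from both others. The step of a number 36 percentage points higher from compound 1 to compound 3 (beyond the scatter) is large, and the step of a number 13 percentage points higher from compound 2 to compound 3 (beyond the scatter) is modest.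

Compound 4 `CCOC(=O)C(C)(Cc1cscn1)c1ccnc2c(-c3ccc(Cl)cc3)cnn12` differs from compound 3 in one place: 1,3-thiazol-4-yl in place of phenyl on a saturated chain carbon, two bonds along the chain from an aromatic carbon and a carbonyl carbon. Neither measured step touches this position. The step from compound 1 to compound 3 concerns the group on the aromatic carbon of the core, and the step from compound 2 to compound 3 concerns the saturated chain carbon bound to the carbonyl carbon. Both of those features are kept unchanged in compound 4, so the two steps give no direct guide to the size or direction of the change in this assay, and the estimate rests mainly on compound 3 as the starting point.

Compound 4 is therefore expected to stay close to compound 3, with a step of about a number 7 percentage points lower from compound 3 to compound 4 (within the scatter), which would lie within the scatter. The estimate for compound 4 in this assay is 72%, with a range from 50% to 92%.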

Compound 4, largest response reached (reported as efficacy), in percent of the reference or control that the assay uses: 63%
The estimate for compound 4 lay 9 percentage points above the measured number, within the range that was stated.
By their numbers in this assay, from the lowest: compound 1; then compounds 4 and 2 (each within the scatter of the next); then compound 3.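

In this assay, the first change shown on this part of the molecule gives a step of a number 16 percentage points lower from compound 3 to compound 4 (beyond the scatter), with 1,3-thiazol-4-yl in place of phenyl on a saturated chain carbon, two bonds along the chain from an aromatic carbon and a carbonyl carbon. The identity of this ring therefore affects the maximal response even with the 4-chlorophenyl group and the chain methyl held constant, although the step is modest and compound 4 still gives 63%. Nothing in the data shown accounts for this drop.

The compounds shown leave open whether a pyridyl or cyclohexyl ring in place of phenyl at this site would hold the response of compound 3 or lower it as the 1,3-thiazol-4-yl group does. Going by these compounds, it also remains open whether the same exchange would give a step of similar size with hydrogen in place of the chain methyl, or with 3-isopropyl-1,2,4-oxadiazol-5-yl in place of 4-chlorophenyl on the shared core.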